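Three Amines and a Fourth Still to Be Measured

This account rests on a few compounds, and the source may have more. Where it says the series, first, only, none or still open, it means among the compounds named here.

compound 1: `C#CCN(Cc1ccccc1)Cc1ccc2ccccc2c1`, 0%
compound 2: `O=C(CN(Cc1ccccc1)Cc1ccc2ccccc2c1)OCCc1ccccc1`, 0%
compound 3: `O=C(CN(Cc1ccccc1)Cc1ccc2ccccc2c1)N1CCCCC1`, 0%

All three measured compounds share one core and were tested in an assay on HEK293 cells for binding affinity to Substance-K receptor (Rattus norvegicus), read by FRET, tested at 10 uM; on this read-out lower numbers stand for less inhibition and higher numbers for more inhibition at the one concentration tested (going by the name of the read-out). Compound 1 gives 0%, compound 2 gives 0% and compound 3 gives 0%, so compound 3 stands level with both of its neighbours; there is no order among the three to speak of.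

The two steps that reach compound 3 say as much. Replacing ethynyl with (piperidin-1-yl)carbonyl on a saturated chain carbon bound to an amine nitrogen gives no change at the digits printed from compound 1 to compound 3 (within the scatter). Replacing phenethyloxy with piperidin-1-yl on a carbonyl carbon gives no change at the digits printed from compound 2 to compound 3 (within the scatter).

Compound 4 is `CN1CCN(C(=O)CN(Cc2ccccc2)Cc2ccc3ccccc3c2)CC1`. It differs from compound 3 as follows: 4-methylpiperazin-1-yl in place of piperidin-1-yl on a carbonyl carbon

Both measured steps bear on this change, since each alters the group on the same carbonyl or the carbonyl itself, and neither moved the read-out beyond the scatter. The change here is of similar kind, an exchange of one ring for another on the carbonyl carbon. No step beyond the scatter is therefore expected, and the expected step is a number 2 percentage points higher from compound 3 to compound 4 (within the scatter).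

Compound 4 is estimated to give 2% in this assay, within a range from -8% to 15%.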

Compound 4, a percentage reported as inhibition, at one concentration (the size of the read-out at that concentration, not a potency): 0%
Beside the measured number, compound 4's estimate is 2 percentage points above it; the measured number falls inside the stated range.
By their numbers in this assay, from the lowest: compounds 1, 2, 3 and 4 (each within the scatter of the next).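

In this assay, placing 4-methylpiperazin-1-yl on the carbonyl carbon in place of piperidin-1-yl gives no change at the digits printed from compound 3 to compound 4 (within the scatter), so this position now has a ring with a second ring nitrogen and a hydrogen-bond acceptor on the entering group, and the read-out still does not separate the two compounds. The same group, set against the other two groups at this place, gives no change at the digits printed from compound 2 to compound 4 (within the scatter) when it replaces phenethyloxy on a carbonyl carbon, and the whole (4-methylpiperazin-1-yl)carbonyl unit gives no change at the digits printed from compound 1 to compound 4 (within the scatter) when it stands in place of ethynyl on a saturated chain carbon bound to an amine nitrogen, which extends the flat picture at this one position to a fourth group. No other measurement is available that bears on this result, and why the four compounds stand level remains unexplained.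

The compounds shown leave open whether any group at this position can raise the inhibition at the one concentration tested, for instance a carboxylic acid on the saturated chain carbon or a longer chain between the carbonyl and the amine nitrogen. They also say nothing about changes elsewhere on the shared core, since all four keep it intact and differ only at this one place.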